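A few compounds are considered here, and "the series" means these few. Any claim that something is new, unique, unknown or untested is made for them only; others in the source may bear on it.

Measured so far in a physicochemical assay for solubility, with a stated time of 4 h, at pH 2.0; a higher number here means a more soluble compound, a lower number a less soluble compound:
- compound 1 `Cc1cc(/C=C/C#N)cc(C)c1Oc1cc(Nc2ccc(C#N)cc2)c(N)cc1C(N)=O`: 2.09 ug/mL
- compound 2 `CC(=O)CCc1cc(C)c(Oc2cc(Nc3ccc(C#N)cc3)c(N)cc2C(F)(F)F)c(C)c1`: 0.28 ug/mL
- compound 3 `Cc1cc(CCC#N)cc(C)c1Oc1cc(Nc2ccc(C#N)cc2)c(N)cc1CO`: 89.8 ug/mL

Compound 1 stands second highest of these three, with compound 2 lower and compound 3 higher, both gaps beyond the usual scatter. Going by the values given here, no two measured compounds differ in one place only, so no measured step is available as a guide. Compound 4 `COC(=O)c1cc(N)c(Nc2ccc(C#N)cc2)cc1Oc1c(C)cc(/C=C/C#N)cc1C` has methoxy in place of amino on a carbonyl carbon, carbamoyl to methoxycarbonyl, relative to compound 1: methoxy in place of amino on a carbonyl carbon. In this assay, a fall modestly beyond the scatter is expected. The expected step is a 2.3-fold lower number from compound 1 to compound 4 (0.37 log units; beyond the scatter). The estimate for compound 4 is 0.9 ug/mL, with an expected range of 0.25 ug/mL to 3.5 ug/mL.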

Compound 4, solubility: 1.75 ug/mL
Compound 4: the middle estimate sits 1.9-fold (0.29 log units) below what was measured, within the range that was stated.
By their numbers in this assay, from the lowest: compound 2; then compounds 4 and 1 (each within the scatter of the next); then compound 3.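

In this assay, going by these compounds alone, the change from carbamoyl to methoxycarbonyl gives a 1.2-fold lower number from compound 1 to compound 4 (0.08 log units; within the scatter), the first step that differs in one place. On this carbonyl carbon, therefore, a hydrogen-bond donor leaves and a hydrogen-bond acceptor enters, with the read-out staying within the scatter on the core of compound 1. Nothing measured alongside this result bears on its cause.

Open, going by these compounds, is whether a carboxylic acid or a dimethylamino group on this carbonyl carbon would also stay within the scatter. Also open, on these data alone, is whether methoxy in place of amino gives a similar step on a core other than that of compound 1.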